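Trifluoromethyl Additions to Pentafluorosulfanyl Anilide Ethers

The source may report more compounds than this note shows. Statements on the series, on what has been measured and on what is new or still open speak of the compounds shown alone.

compound 1 `CC(O)(COc1ccc(C#N)cc1)C(=O)Nc1ccc(S(F)(F)(F)(F)F)cc1`: 100000 nM
compound 2 `CC(O)(COc1ccc(C#N)cc1C(F)(F)F)C(=O)Nc1ccc(S(F)(F)(F)(F)F)cc1`: 100000 nM
compound 3 `CC(O)(COc1cccc(C(F)(F)F)c1)C(=O)Nc1cccc(S(F)(F)(F)(F)F)c1`: 22500 nM

In a functional assay on VCaP cells (Homo sapiens) for antiproliferative activity, read by propidium iodide staining, with a stated time of 96 h (a higher number here means a weaker inhibitor, a lower number a stronger inhibitor), compound 1 gives 100000 nM and compound 2 gives 100000 nM. The change trifluoromethyl in place of hydrogen on an aromatic carbon produced no change at the digits printed from compound 1 to compound 2 (within the scatter). Compound 3 gives 22500 nM in this assay, the lowest of the three numbers. The difference between the core of compound 3 and the core of compound 1 is not broken down here.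

Compound 4 `CC(O)(COc1cc(C(F)(F)F)cc(C(F)(F)F)c1)C(=O)Nc1cccc(S(F)(F)(F)(F)F)c1` arises from compound 3 by trifluoromethyl in place of hydrogen on an aromatic carbon. This is the same kind of change as before, but the surroundings differ: here the entering group sits meta to a large group and meta to a trifluoromethyl group, whereas in compound 2 it sits ortho to a large group and meta to a cyano group. Because the earlier step was no change at the digits printed from compound 1 to compound 2 (within the scatter), only a small step is expected in this assay: a 1.3-fold lower number from compound 3 to compound 4 (0.12 log units; within the scatter). Compound 4 is therefore estimated at 17000 nM, with a likely range from 5000 nM to 60000 nM.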

Compound 4, half-maximal inhibitory concentration: 2800 nM
Beside the measured number, compound 4's estimate is 6.1-fold (0.78 log units) above it, outside the stated range (below it).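

Trifluoromethyl in place of hydrogen on an aromatic carbon gives an 8.0-fold lower number from compound 3 to compound 4 (0.91 log units; beyond the scatter) in this assay. The step on one core therefore did not predict the step on the other: the same change on two cores in this assay, no change at the digits printed (within the scatter) from compound 1 to compound 2 and an 8.0-fold lower number (0.91 log units; beyond the scatter) from compound 3 to compound 4, 8.0-fold (0.91 log units) apart, beyond the scatter of two such steps

This shows that the change cannot be carried between these cores at a fixed size. It does not show why, since the two pairs differ both in their cores and in the groups around the entering trifluoromethyl, and two pairs give no general rule.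

The compounds shown leave open whether a chlorine atom or a methoxy group in the same place on compound 3 would give a step of similar size. They also leave open how the same change behaves on further cores.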